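The source may report more compounds than this note shows. Statements on the series, on what has been measured and on what is new or still open speak of the compounds shown alone.

Series of chalcones around the shared core of compound 1, all tested in an assay on isolated protein for inhibition of Amine oxidase [flavin-containing] B (Homo sapiens); on this read-out higher numbers stand for weaker inhibition and lower numbers for stronger inhibition.

Going by the values given here, compound 1 `CCOc1ccc(C(=O)/C=C/c2ccc(N(C)C)cc2)cc1` gives 210 nM in this assay and is the only member with a numerical value. Compound 2 `COc1cccc(/C=C/C(=O)c2ccc(O/N=C(\C)c3cccs3)cc2)c1` reaches only a limit of the assay, < 300 nM in this assay. Compound 3 `COc1ccc(C(=O)/C=C/c2ccc(O/N=C(\C)c3ccccc3)cc2)cc1` likewise gives a limit, > 200 nM in this assay, and no number. Among the compounds with values here, both limits are marked by the limit of < 300 nM in this assay, at which 1 of the 3 values shown sits, and (the limit of > 200 nM in this assay, at which 1 of the 3 values shown sits), so compound 1 can be placed against neither with certainty, and no step between measured compounds is available.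

The next compound to be measured is compound 4 `CCOc1ccc(C(=O)/C=C/c2ccc([N+](=O)[O-])cc2)cc1`, which differs from compound 1 by nitro in place of dimethylamino on an aromatic carbon, on an aromatic carbon of a six-membered aromatic ring of carbon only, para to a large group. Within the data shown here, with no measured step to lean on, the expectation for this assay rests on the single number of compound 1 alone, and the change is expected to shift the value only modestly, towards weaker inhibition by about a 2.1-fold higher number from compound 1 to compound 4 (0.33 log units; beyond the scatter), a step at the edge of the scatter rather than clearly beyond it. Compound 4 is therefore estimated at 450 nM, within the range 120 nM to 1800 nM in this assay.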

Compound 4, half-maximal inhibitory concentration: 210 nM
For compound 4 the middle estimate is 2.1-fold (0.33 log units) above the measured one; the measured number falls inside the stated range.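

Going by these compounds alone, the first step that can be read in this assay shows no change at the digits printed from compound 1 to compound 4 (within the scatter), so at this place, on an aromatic carbon para to a large group, nitro in place of dimethylamino leaves the read-out where it stood. The two groups both have 3 heavy atoms, but the exchange takes the count of hydrogen-bond acceptors from 1 to 2 and adds a double bond outside the aromatic rings, and neither difference comes with any change in the value for this pair. Nothing among the measurements shown gives a reason for this flat step.

As far as these compounds go, whether the same flat response holds for other groups at this place, such as a carboxylic acid or a primary amine, stays open, and a single pair cannot establish a pattern for the series. Compound 2 and compound 3 differ from compound 1 in more than one place and each carries only a limit of the assay, so steps to them cannot be read.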